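Cytotoxicity in fibroblasts: three compounds measured, one expected

The source may hold more compounds than are shown below. What is called first, only, known or untested is meant among the compounds shown, and "the series" means these compounds.

Measured in an ADME assay on BJ cells (Homo sapiens) for cytotoxicity, with a stated time of 72 h; on this read-out lower numbers stand for an effect already at smaller amounts and higher numbers for an effect only at larger amounts of compound:
- Compound 1 `CCc1ccc(-c2nc3c(c(C)nn3-c3ccccc3)c(-c3ccccc3Cl)c2C#N)cc1`: > 20000 nM, a limit of the assay.
- Compound 2 `CCc1ccc(-c2nc3c(c(C)nn3-c3ccccc3)c(-c3ccccc3)c2C#N)cc1`: > 20000 nM, a limit of the assay.
- Compound 3 `Cc1ccc(-c2nc3c(c(C)nn3-c3ccccc3)c(-c3ccccc3O)c2C#N)cc1`: 22200 nM.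

Within the data shown here, compound 3 stands as the only number in this assay; the other two results are limits. Among the measured compounds shown here, the single step between measured compounds, a step that the two limits leave unreadable from compound 1 to compound 2, cannot be read in size, since the limit of > 20000 nM in this assay, at which 2 of the 3 values shown sit, describes where both of its values sit.

Compound 4 `Cc1nn(-c2ccccc2)c2nc(-c3ccc4c(c3)OCCO4)c(C#N)c(-c3ccccc3O)c12` differs from compound 3 in one place: 2,3-dihydro-1,4-benzodioxin-6-yl in place of 4-methylphenyl on an aromatic carbon. For the measured compounds named here, no measured step touches this change, and the one step that is known is unreadable, so the data give no basis for expecting a move in either direction beyond the scatter. In this assay compound 4 is therefore expected near 20000 nM, within a range from 8000 nM to 50000 nM. This corresponds to an expected step of a 1.1-fold lower number from compound 3 to compound 4 (0.05 log units; within the scatter), within the scatter, and a fair chance that only a limit is reported.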

Compound 4, half-maximal effective concentration: > 20000 nM
Compound 4 gave a limit, no number; the forecaster's own chance of this, stated with the estimate: 50%; the middle value lies on the limit itself.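

In this assay compound 4 gives > 20000 nM, a limit of the assay and not a number. The step from compound 3 to compound 4 therefore cannot be read in size: the limit of > 20000 nM in this assay, at which 3 of the 4 values shown sit.

The compounds shown leave open whether 2,3-dihydro-1,4-benzodioxin-6-yl in place of 4-methylphenyl changes the value in either direction, and where compound 1, compound 2 and compound 4 would fall as numbers.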